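The compounds below may be only part of what the source reports. "The series", "measured", "known", "first", "only" and "open" are said of these compounds alone.

Three compounds share a hexafluoro-hydroxy-propyl group on a phenol. Compound 1 `Cc1ccc(O)c(C(O)(C(F)(F)F)C(F)(F)F)c1` is the smallest of them; in an assay on isolated protein for inhibition of receptor-type tyrosine-protein phosphatase C (Homo sapiens), read by spectrophotometry (on this read-out higher numbers stand for weaker inhibition and lower numbers for stronger inhibition), compound 1 gives 207000 nM. Compound 2 `O=C(COc1ccc2cc(C(O)(C(F)(F)F)C(F)(F)F)c(O)cc2c1)Nc1nc2ccccc2s1` carries the same group on a larger core with an ether-linked amide; in this assay compound 2 gives 10900 nM, the lowest of the three numbers. Compound 3 `Cc1ccc(S(=O)(=O)NNC(=O)COc2ccc3cc(C(O)(C(F)(F)F)C(F)(F)F)c(O)cc3c2)cc1` differs from compound 2 only at the amide nitrogen, and in this assay compound 3 gives 16100 nM; the change is a 1.5-fold higher number from compound 2 to compound 3 (0.17 log units; within the scatter), so the two cannot be told apart. Compound 4 `O=C(COc1ccc2cc(C(O)(C(F)(F)F)C(F)(F)F)c(O)cc2c1)Nc1cccc2ccccc12` keeps the core of compound 2 and alters the same amide nitrogen: naphthalen-1-yl in place of 1,3-benzothiazol-2-yl on an amide-type nitrogen. Among the measured compounds shown here, only the step from compound 2 to compound 3 bears on this, and that step stayed within the scatter, so the amide substituent has so far mattered little. Compound 4 is therefore expected to give 12000 nM, with a range from 5000 nM to 30000 nM, a step of a 1.1-fold higher number from compound 2 to compound 4 (0.04 log units; within the scatter) that is expected to stay within the scatter.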

Compound 4, half-maximal inhibitory concentration: 29100 nM
The estimate for compound 4 lay 2.4-fold (0.38 log units) below the measured number; the measured number falls inside the stated range.
By their numbers in this assay, from the lowest: compounds 2, 3 and 4 (each within the scatter of the next, the first and the last beyond it); then compound 1.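

In this assay, the substituent on the amide-type nitrogen turns out to matter after all: naphthalen-1-yl in place of 1,3-benzothiazol-2-yl gives a 2.7-fold higher number from compound 2 to compound 4 (0.43 log units; beyond the scatter) for this change, a modest step but the first at this position to pass the scatter. Set against the ((4-methylphenyl)sulfonyl)amino group, naphthalen-1-yl gives a 1.8-fold higher number from compound 3 to compound 4 (0.26 log units; within the scatter) and so cannot be told apart from it, which means only the benzothiazole compound separates from the naphthalene one. No measurement here links this step to any particular feature of the two groups. The change swaps a ring holding nitrogen and sulfur for an all-carbon ring, so those atoms cannot be judged apart from the change of ring shape. Still open, on these data alone, is what a plain phenyl on this nitrogen would give, and whether a carboxylic acid in place of the whole amide would keep the inhibition.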